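The source may hold more compounds than are shown below. What is called first, only, known or untested is meant among the compounds shown, and "the series" means these compounds.

Measured compounds:
compound 1, `CCOC(=O)CN(C)CC#Cc1cc2ncnc(Nc3ccc(OCc4cccc(F)c4)c(Cl)c3)c2s1`, 26 uM in an ADME assay on HepG2 cells (Homo sapiens) for cytotoxicity; on this read-out lower numbers stand for higher toxicity in this test and higher numbers for lower toxicity in this test
compound 2, `CC(C)(C)CC#Cc1cc2ncnc(Nc3ccc(OCc4cccc(F)c4)c(Cl)c3)c2s1`, 29.3 uM in this assay
compound 3, `CCOC(=O)CN(C)CC#Cc1cc2c(Nc3ccc(OCc4cccc(F)c4)c(Cl)c3)ncnc2s1`, a limit of the test rather than a number, > 28 uM in this assay

Compound 1 and compound 2 share one core and differ by one change, (tert-butyl in place of ((ethoxycarbonyl)methyl)(methyl)amino on a saturated chain carbon bound to a triple-bonded carbon). That change gave a 1.1-fold higher number from compound 1 to compound 2 (0.05 log units; within the scatter), so the two values show no real difference in this test. Compound 3 is built from the same atoms as compound 1 joined differently; the difference between the two cores is not broken down here. For compound 3 the test reached only (the limit of > 28 uM in this assay, at which 1 of the 3 values shown sits).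

Compound 4, `CC(C)(C)CC#Cc1cc2c(Nc3ccc(OCc4cccc(F)c4)c(Cl)c3)ncnc2s1`, has not yet been measured in this assay. It stands to compound 3 as compound 2 stands to compound 1: the same change, (tert-butyl in place of ((ethoxycarbonyl)methyl)(methyl)amino on a saturated chain carbon bound to a triple-bonded carbon), at the same place. Because the earlier step was a 1.1-fold higher number from compound 1 to compound 2 (0.05 log units; within the scatter), the expected step is a step that the limit leaves unreadable from compound 3 to compound 4, that is, essentially no change. Compound 4 is therefore expected to give about 32 uM in this assay, and the test may again report only a limit.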

Compound 4, half-maximal toxic concentration: > 32 uM
Compound 4 gave a limit, no number; the forecaster's own chance of this, stated with the estimate: 55%; the middle value lies on the limit itself.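

Compound 3 and compound 4 both gave only limits, not numbers, in this assay, so the step between them cannot be read. The compounds shown leave open whether tert-butyl in place of ((ethoxycarbonyl)methyl)(methyl)amino shifts the half-maximal toxic concentration at all on the core of compound 3, where the true values of both compounds remain unknown.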